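A Carboxyl Side Chain on a Weakly Cytotoxic Amide

The source may report more compounds than this note shows. Statements on the series, on what has been measured and on what is new or still open speak of the compounds shown alone.

Compound 1 `NCCNC(=O)Cn1nc(N)c2c(C(F)(F)F)cc(-c3ccccc3)nc21` gives 38900 nM in a functional assay on DU-145 cells (Homo sapiens) for cytotoxicity, read by MTT assay, with a stated time of 24 h (a lower number here means a stronger inhibitor, a higher number a weaker inhibitor), the highest number among the three measured compounds. Compound 2 `Nc1nn(CC(=O)NCc2ccco2)c2nc(-c3ccccc3)cc(C(F)(F)F)c12` gives 5600 nM and compound 3 `CN1CCN(C(=O)Cn2nc(N)c3c(C(F)(F)F)cc(-c4ccccc4)nc32)CC1` gives 18100 nM. Compound 4 `CC(NC(=O)Cn1nc(N)c2c(C(F)(F)F)cc(-c3ccccc3)nc21)C(=O)O` differs from compound 1 in one place: 1-carboxyethyl in place of 2-aminoethyl on an amide-type nitrogen. Both measured changes to the same side chain of compound 1 lowered the number: a 6.9-fold lower number from compound 1 to compound 2 (0.84 log units; beyond the scatter) and a 2.1-fold lower number from compound 1 to compound 3 (0.33 log units; beyond the scatter). The entering 1-carboxyethyl group resembles neither of those replacements, so the direction of the new step is uncertain; a modest lowering or no step beyond the scatter seems most plausible. Compound 4 is therefore expected to give about 30000 nM, within 12000 nM to 80000 nM, meaning that a 1.3-fold lower number from compound 1 to compound 4 (0.11 log units; within the scatter) is expected.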

Compound 4, half-maximal inhibitory concentration: 22400 nM
Compound 4: middle estimate off by 1.3-fold (0.13 log units), on the high side, within the range that was stated.
By their numbers in this assay, from the lowest: compound 2; then compounds 3, 4 and 1 (each within the scatter of the next, the first and the last beyond it).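

Putting 1-carboxyethyl in place of 2-aminoethyl on the amide-type nitrogen gives no step beyond the scatter in this assay (a 1.7-fold lower number from compound 1 to compound 4 (0.24 log units; within the scatter)), so a chain carrying a carboxylic acid reads the same here as one carrying an amine. The same holds against 4-methylpiperazin-1-yl on the carbonyl carbon (a 1.2-fold higher number from compound 3 to compound 4 (0.09 log units; within the scatter)), while (furan-2-yl)methyl stays clearly apart (a 4.0-fold higher number from compound 2 to compound 4 (0.60 log units; beyond the scatter)), and of these side chains only that one separates from the others. Nothing measured here explains these numbers. Open, as far as these compounds go, is whether a benzyl or a (thiophen-2-yl)methyl group on the same nitrogen would match (furan-2-yl)methyl. Also open, from the compounds shown here alone, is whether the methyl ester of the carboxylic acid would read differently from compound 4.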